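Moving the chlorine on the anilide ring of thioester analogues

This account rests on a few compounds, and the source may have more. Where it says the series, first, only, none or still open, it means among the compounds named here.

Two pairs of compounds share one change: a 3-chlorophenyl in place of a 2-chlorophenyl on the amide-type nitrogen. Compound 1 `CC(=O)SCCC(CCCCC(=O)Nc1ccccc1Cl)SC(C)=O` and compound 2 `CC(=O)SCCC(CCCCC(=O)Nc1cccc(Cl)c1)SC(C)=O` carry acetyl thioesters; compound 3 `O=C(CCCCC(CCSC(=O)c1ccccc1)SC(=O)c1ccccc1)Nc1ccccc1Cl` and compound 4 `O=C(CCCCC(CCSC(=O)c1ccccc1)SC(=O)c1ccccc1)Nc1cccc(Cl)c1` carry benzoyl thioesters. How the two cores differ is not broken down here.

In a functional assay on NCI-H460 cells (Homo sapiens) for inhibition, read by MTT assay, with a stated time of 24 h, tested at 1 ug/mL (a lower number here means less inhibition of growth, a higher number more inhibition of growth at the concentration tested), compound 1 gives 13.2%, while compound 2 gives 0.31%. The change 3-chlorophenyl in place of 2-chlorophenyl on an amide-type nitrogen thus lowered the read-out, a number 12.9 percentage points lower from compound 1 to compound 2 (beyond the scatter). Compound 3 gives 14.4% in this assay, and its value and that of compound 1 lie within the scatter of each other.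

Compound 4 has not yet been measured. It differs from compound 3 by 3-chlorophenyl in place of 2-chlorophenyl on an amide-type nitrogen, the same change at the same place as from compound 1 to compound 2. Because the step of a number 12.9 percentage points lower from compound 1 to compound 2 (beyond the scatter) was a drop beyond the scatter, a drop of similar size is expected here, a number 11.9 percentage points lower from compound 3 to compound 4 (beyond the scatter). Going by the values given here, compound 4 is therefore estimated at 2.5% in this assay, with a likely range from 0% to 12%, resting on only one earlier example.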

Compound 4, percent growth inhibition at one concentration: 9.48%
Beside the measured number, compound 4's estimate is 7 percentage points below it; the range from low to high includes it.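

In this assay, the 3-chlorophenyl in place of the 2-chlorophenyl on the amide-type nitrogen of the benzoyl thioester core gives a number 4.9 percentage points lower from compound 3 to compound 4 (within the scatter). Set side by side, the steps on the two cores cannot be told apart: the same change on two cores in this assay, a number 12.9 percentage points lower (beyond the scatter) from compound 1 to compound 2 and a number 4.9 percentage points lower (within the scatter) from compound 3 to compound 4, 8 percentage points apart, within the scatter of two such steps So the four compounds give no sign that the change behaves differently on the acetyl and benzoyl thioester cores, but they do not show that it behaves the same, since there are only two pairs, tested at a single concentration, and the step on the benzoyl core cannot be separated from the scatter on its own.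

Going by these compounds, it remains open whether the change would carry over to other thioesters, such as a longer hexanoyl chain, or to free thiols in place of the thioesters. The compounds shown also leave open what happens when fluorine or a methyl group takes the place of the chlorine on the ring.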